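Para substituent on the aryl-triazole: three points, one gap

The source may hold more compounds than are shown below. What is called first, only, known or untested is meant among the compounds shown, and "the series" means these compounds.

Three compounds share the core of compound 1 `CC(C)c1ccc(-n2cc(-c3cn([C@H]4C[C@H](O)[C@@H](CO)O4)c(=O)[nH]c3=O)nn2)cc1` and differ only in the group on the aromatic carbon of the outer ring. In an ADME assay on L1210 cells (Mus musculus) for cytotoxicity, read by cell counting, with a stated time of 2 days (a higher number here means a weaker inhibitor, a lower number a stronger inhibitor), compound 1 gives 29000 nM. Compound 2 `O=c1[nH]c(=O)n([C@H]2C[C@H](O)[C@@H](CO)O2)cc1-c1cn(-c2ccc(Br)cc2)nn1` gives 4600 nM in this assay, the step of a 6.3-fold lower number from compound 1 to compound 2 (0.80 log units; beyond the scatter). Compound 3 `CSc1ccc(-n2cc(-c3cn([C@H]4C[C@H](O)[C@@H](CO)O4)c(=O)[nH]c3=O)nn2)cc1` gives 62000 nM, the highest of the three numbers; the steps are a 2.1-fold higher number from compound 1 to compound 3 (0.33 log units; beyond the scatter) and a 13-fold higher number from compound 2 to compound 3 (1.13 log units; beyond the scatter).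

Compound 4 `O=c1[nH]c(=O)n([C@H]2C[C@H](O)[C@@H](CO)O2)cc1-c1cn(-c2ccc(Oc3ccccc3)cc2)nn1` carries the change (phenoxy in place of methylsulfanyl on an aromatic carbon). Among the compounds with values here, no measured step involves phenoxy; the steps that bear on the question are the three para-group swaps above, which run from modest to large. The direction for a seven-heavy-atom aromatic group cannot be read off cleanly from the two smaller groups, so the expectation is a modest lowering with wide uncertainty: compound 4 is estimated at 30000 nM in this assay, between 8000 nM and 120000 nM, which means an expected step of a 2.1-fold lower number from compound 3 to compound 4 (0.32 log units; beyond the scatter).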

Compound 4, half-maximal inhibitory concentration: 500 nM
Beside the measured number, compound 4's estimate is 60-fold (1.78 log units) above it, and the stated range ends above it.
By their numbers in this assay, from the lowest: compound 4; then compound 2; then compound 1; then compound 3.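

In this assay, within the data shown here, this position on the aromatic carbon is not limited to small groups: phenoxy, the only one of the four groups with a ring of its own, goes with a 120-fold lower number from compound 3 to compound 4 (2.09 log units; beyond the scatter) and with a 58-fold lower number from compound 1 to compound 4 (1.76 log units; beyond the scatter) as well. Even bromo, the lowest of the earlier three, is passed, with a 9.2-fold lower number from compound 2 to compound 4 (0.96 log units; beyond the scatter) and so the spread at this one position reaches well beyond what the three smaller groups covered. Nothing at hand accounts for this order of groups.

Going by these compounds, it stays open whether the aromatic ring or the linking oxygen of phenoxy goes with the lower number; a directly attached phenyl or a benzyl group would separate the two. The compounds shown also leave open whether a chlorine or an amine on the outer ring of phenoxy would move the number further.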